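Aryl replacement on the shared core: compound 1 to compound 4

The source may report more compounds than this note shows. Statements on the series, on what has been measured and on what is new or still open speak of the compounds shown alone.

Measured so far in a functional assay on MCF7 cells (Homo sapiens) for inhibition; on this read-out higher numbers stand for weaker inhibition and lower numbers for stronger inhibition:
- compound 1, `CC/C(=C(/c1ccc(/C=C/C(=O)O)cc1)c1cc2ccccc2[nH]1)c1cccc(C)c1`: 140 nM
- compound 2, `CC/C(=C(/c1ccc(/C=C/C(=O)O)cc1)c1cc2ccccc2[nH]1)c1ccc(C#N)cc1`: 278 nM
- compound 3, `CC/C(=C(/c1ccc(/C=C/C(=O)O)cc1)c1cc2ccccc2[nH]1)c1ccc(Cl)cc1Cl`: 11 nM

Compound 1 stands second highest of the three numbers; compound 2 lies nearest with a 2.0-fold higher number from compound 1 to compound 2 (0.30 log units; within the scatter), and compound 3 lies furthest with a 13-fold lower number from compound 1 to compound 3 (1.10 log units; beyond the scatter). Compound 4, `CC/C(=C(/c1ccc(/C=C/C(=O)O)cc1)c1cc2ccccc2[nH]1)c1ccc(Cl)c(C(F)(F)F)c1`, is not yet measured. The change from compound 1 is 4-chloro-3-(trifluoromethyl)phenyl in place of 3-methylphenyl on a double-bonded chain carbon bound to a double-bonded chain carbon and a saturated chain carbon. Among the compounds with values here, the steps that bear on it are a 13-fold lower number from compound 1 to compound 3 (1.10 log units; beyond the scatter) and a 25-fold lower number from compound 2 to compound 3 (1.40 log units; beyond the scatter), both beyond the scatter and both toward lower numbers when chlorine-bearing phenyl enters at that place; no measured step carries a trifluoromethyl group. A step toward a lower number in this assay is therefore expected for compound 4, a 3.5-fold lower number from compound 1 to compound 4 (0.54 log units; beyond the scatter), though smaller than that seen for compound 3. Compound 4 is estimated at 40 nM, with a range of 12 nM to 140 nM.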

Compound 4, half-maximal inhibitory concentration: 2200 nM
Compound 4: the middle estimate sits 55-fold (1.74 log units) below what was measured; measured number above the stated range.
By their numbers in this assay, from the lowest: compound 3; then compounds 1 and 2 (each within the scatter of the next); then compound 4.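

A 4-chloro group on the aryl ring at this place does not by itself give a lower number in this assay: 4-chloro-3-(trifluoromethyl)phenyl goes the opposite way to 2,4-dichlorophenyl (a 16-fold higher number from compound 1 to compound 4 (1.20 log units; beyond the scatter); a 200-fold higher number from compound 3 to compound 4 (2.30 log units; beyond the scatter)). It also ends above the 4-cyanophenyl of compound 2 (a 7.9-fold higher number from compound 2 to compound 4 (0.90 log units; beyond the scatter)), so the aryl group at this place moves the number strongly in both directions. Nothing at hand explains the rise seen with compound 4.

As far as these compounds go, it remains open whether the rise goes with the trifluoromethyl group alone or with its combination with chlorine. A 3-(trifluoromethyl)phenyl and a plain 4-chlorophenyl at this place would separate the two.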